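Urea aryl swap: dichlorophenyl to trifluoromethylphenyl

A few compounds are considered here, and "the series" means these few. Any claim that something is new, unique, unknown or untested is made for them only; others in the source may bear on it.

Three members of the series have numbers in a functional assay on MCF7 cells (Homo sapiens) for inhibition, read by sulforhodamine B assay, with a stated time of 48 h, tested at 1 uM; on this read-out higher numbers stand for a weaker effect at the one concentration tested and lower numbers for a stronger effect. Compound 1 `COc1cc(Cl)cc(-c2nn(-c3cccc(NC(=O)Nc4ccc(Cl)c(C(F)(F)F)c4)c3)cc2-c2ccncc2)c1` gives 50%. Compound 2 `COc1cc(Cl)cc(-c2nn(-c3cccc(NC(=O)Nc4cc(C(F)(F)F)cc(C(F)(F)F)c4)c3)cc2-c2ccncc2)c1` gives 21%. Compound 3 `COc1cc(Cl)cc(-c2nn(-c3cccc(NC(=O)Nc4ccc(Cl)c(Cl)c4)c3)cc2-c2ccncc2)c1` gives 83%, the highest of the three, beyond the scatter above compound 1 and further still above compound 2. Within the data shown here, the single one-place step so far is a number 33 percentage points higher from compound 1 to compound 3 (beyond the scatter): putting chloro where trifluoromethyl stood raised the number sharply.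

Compound 4 `COc1cc(Cl)cc(-c2nn(-c3cccc(NC(=O)Nc4cccc(C(F)(F)F)c4)c3)cc2-c2ccncc2)c1` has no value yet in this assay. It differs from compound 3 by 3-(trifluoromethyl)phenyl in place of 3,4-dichlorophenyl on an amide-type nitrogen. This change removes one chloro and exchanges the other for trifluoromethyl, which runs opposite to a number 33 percentage points higher from compound 1 to compound 3 (beyond the scatter). Compound 2, which carries trifluoromethyl twice on that ring, also sits well below compound 3. Among the measured compounds shown here, both observations point to a lower number for compound 4 than for compound 3, and the single trifluoromethyl of compound 4 suggests a position nearer compound 1 than compound 2. Compound 4 is therefore estimated at 45%, with a range of 25% to 68%. For the measured compounds named here, the expected step is a number 38 percentage points lower from compound 3 to compound 4 (beyond the scatter), downward and beyond the scatter, though the loss of the second chloro has no direct precedent among the measured compounds.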

Compound 4, a percentage reported as activity, at one concentration (the size of the read-out at that concentration, not a potency): 62%
Compound 4: middle estimate off by 17 percentage points, on the low side, within the range that was stated.
By their numbers in this assay, from the lowest: compound 2; then compound 1; then compound 4; then compound 3.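

In this assay, compound 4 gives this position a reference ring with a single trifluoromethyl, against which the second substituent can be read: a number 41 percentage points higher from compound 2 to compound 4 (beyond the scatter) when hydrogen replaces trifluoromethyl, and a number 12 percentage points higher from compound 1 to compound 4 (beyond the scatter) when hydrogen replaces chloro. Both steps run upward, so on this ring a second substituent of either kind goes with a stronger effect at the one concentration tested, and the step for trifluoromethyl is the large one while that for chloro is modest. The 3,4-dichlorophenyl of compound 3 does not fit a simple count of substituents, since a number 21 percentage points lower from compound 3 to compound 4 (beyond the scatter) when 3-(trifluoromethyl)phenyl enters, so the ring with one substituent still gives a lower number than the ring with two chloro groups; among these four compounds, each ring bearing trifluoromethyl lies below compound 3, with none against that order.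

Still open, from the compounds shown here alone, is how a ring with one chloro alone, or with a nitrile, a methoxy or an amine in place of trifluoromethyl, would fall within this order. Nothing available bears on why the steps differ in size.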